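This account rests on a few compounds, and the source may have more. Where it says the series, first, only, none or still open, it means among the compounds named here.

Compound 1 `CC1=NN(C(=O)CCl)C(c2cc(Br)ccc2O)C1`: 9210 nM
Compound 2 `CC1=NN(S(=O)(=O)c2ccccc2)C(c2cc(Br)ccc2O)C1`: 55600 nM
Compound 3 `CC1=NN(S(=O)(=O)c2ccc([N+](=O)[O-])cc2)C(c2cc(Br)ccc2O)C1`: 27300 nM

In a functional assay on SGC-7901 cells (Homo sapiens) for antiproliferative activity, read by MTT assay, with a stated time of 48 h (on this read-out higher numbers stand for an effect only at larger amounts of compound and lower numbers for an effect already at smaller amounts), compound 3 gives 27300 nM, the second highest of the three numbers, with compound 2 higher and compound 1 lower. Compound 4 `CC1=NN(S(=O)(=O)c2ccc(Cl)cc2)C(c2cc(Br)ccc2O)C1` carries chloro in place of nitro on an aromatic carbon. Going by the values given here, only one measured step touches this place: a 2.0-fold lower number from compound 2 to compound 3 (0.31 log units; beyond the scatter), a modest change on putting nitro in place of hydrogen. Among the compounds with values here, no chloro compound has been measured, so the direction stays open, and no step beyond the scatter is expected in this assay. The expected step is a 1.1-fold higher number from compound 3 to compound 4 (0.04 log units; within the scatter). For compound 4 the estimated value is 30000 nM, with an expected range of 13000 nM to 65000 nM.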

Compound 4, half-maximal effective concentration: > 60000 nM
Compound 4 was reported as a limit; the forecaster's own chance of this, stated with the estimate: 10%; middle value at least 2.0-fold (0.30 log units) away from the limit.
By their numbers in this assay, from the lowest: compound 1; then compound 3; then compound 2. At a limit, above all of these: compound 4.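

Going by these compounds alone, at this place, para to a large group, the earlier compounds showed only that nitro gives a lower number than hydrogen. Now an at least 2.1-fold higher number from compound 3 to compound 4 (0.34 log units; beyond the scatter) in this assay shows that chloro does not keep that gain, so not every group placed here lowers the number. For chloro against hydrogen, an at least 1.0-fold higher number from compound 2 to compound 4 (0.03 log units; that floor lies within the scatter) settles little, because this value is a limit: the limit of > 60000 nM in this assay, at which 1 of the 4 values shown sits.

From the compounds shown here alone, whether an amine or a carboxylic acid at this place would fall nearer compound 3 or compound 4 stays open. So does the true value of compound 4 beyond its limit.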